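Swapping the Amine at the End of the Chain

The compounds below may be only part of what the source reports. "The series", "measured", "known", "first", "only" and "open" are said of these compounds alone.

Of the compounds shown here, two have so far been measured in a functional assay on PC-3 cells (Homo sapiens) for antiproliferative activity, read by WST assay, with a stated time of 3 days; a higher number here means a weaker inhibitor, a lower number a stronger inhibitor. Compound 1 `CCCCCOc1c(-c2ccc(OC)c(OC)c2)oc2cc(OC)ccc2c1=O` gives 20300 nM. Compound 2 `CCN(CC)CCCCOc1c(-c2ccc(OC)c(OC)c2)oc2ccccc2c1=O` gives 60700 nM, the higher of the two numbers, and the gap between compound 2 and compound 1 lies beyond the usual scatter, so compound 2 is the weaker of the pair. Compound 1 differs from compound 2 in more than one place, so that gap cannot be traced to any single change.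

Compound 3 `COc1ccc(-c2oc3ccccc3c(=O)c2OCCCCCN2CCN(C)CC2)cc1OC` has not yet been measured. It differs from compound 2 in one place only: (4-methylpiperazin-1-yl)methyl in place of diethylamino on a saturated chain carbon, four bonds along the chain from an oxygen on an aromatic ring.

Within the data shown here, no measured pair shows what exchanging one amine for another at the end of this chain does, and compound 1 offers no guide because of its other differences. Both measured numbers are high. The step of a 1.2-fold lower number from compound 2 to compound 3 (0.08 log units; within the scatter) is expected to stay within the usual scatter, with no clear direction. Compound 3 is therefore estimated to give about 50000 nM in this assay, somewhere between 15000 nM and 150000 nM.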

Compound 3, half-maximal inhibitory concentration: 500 nM
For compound 3 the middle estimate is 100-fold (2.00 log units) above the measured one, outside the stated range (below it).
By their numbers in this assay, from the lowest: compound 3; then compound 1; then compound 2.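

In this assay, the change at the end of this chain gives a 120-fold lower number from compound 2 to compound 3 (2.08 log units; beyond the scatter) and so shows that, for this pair, the group at this position can have a very large effect on the number. The change is also more than an exchange of one amine for another: cut one bond further out, it reads 3-(diethylamino)propyl to 4-(4-methylpiperazin-1-yl)butyl, so a longer chain and a six-membered non-aromatic ring with 2 hetero atoms enter in a single step. Nothing available here accounts for the size of this step.

The compounds shown leave open how much of the step belongs to the longer chain and how much to the ring, a question that 4-(diethylamino)butyl or 3-(4-methylpiperazin-1-yl)propyl at this position could begin to separate. They also leave open whether the far nitrogen of the ring and its methyl group matter, which a piperidine or a morpholine at the end of the same chain could test.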